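The source may report more compounds than this note shows. Statements on the series, on what has been measured and on what is new or still open speak of the compounds shown alone.

Measured so far:
- compound 1 `Cc1ncccc1N1C[C@]2(CC[C@@H](CNc3cnn(-c4ccccc4F)c3)CC2)OC1=O`: "not determined" (no result reported)
- compound 2 `O=C1O[C@]2(CC[C@H](CNc3ncc(-c4ccccc4F)cn3)CC2)CN1c1ccccn1`: < 0.01

In an ADME assay on brain (Rattus norvegicus) for protein binding (on this read-out lower numbers stand for a smaller free fraction and higher numbers for a larger free fraction), compound 1 has no number to stand on, its entry being "not determined" (no result reported). Within the data shown here, the only other entry is compound 2 at < 0.01, which is a limit of the assay and not a number. That leaves the series with one reading: the limit of < 0.01 in this assay, at which 1 of the 2 values shown sits.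

Compound 3 `O=C1O[C@]2(CC[C@H](CNc3cnn(-c4ccccc4F)c3)CC2)CN1c1cncnc1` keeps the core of compound 1 and changes one group. The change is pyrimidin-5-yl in place of 2-methylpyridin-3-yl on an amide-type nitrogen in a ring, with pyrimidin-5-yl in place of 2-methylpyridin-3-yl on an amide-type nitrogen in a ring. No measured pair sizes this change, so the expectation is modest: no step beyond the usual scatter in this assay, in either direction. For compound 3 the expected unbound fraction is 0.015, with an estimated range of 0.006 to 0.04.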

Compound 3, unbound fraction: 0.044
Beside the measured number, compound 3's estimate is 2.9-fold (0.47 log units) below it; the measured number lies above the stated range.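

No step can be read from compound 3: compound 1 has no numeric result, and compound 2 differs from compound 3 in more than one place. Among these compounds, the only other reading is a limit of the assay, held by compound 2: the limit of < 0.01 in this assay, at which 1 of the 3 values shown sits. Still open, going by these compounds, is how far pyrimidin-5-yl in place of 2-methylpyridin-3-yl shifts the unbound fraction on an otherwise unchanged core.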